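Alkyl chain variation on the shared core: working notes

The source may hold more compounds than are shown below. What is called first, only, known or untested is meant among the compounds shown, and "the series" means these compounds.

Measured so far:
compound 1, `CC(C)c1cn([C@H]2C[C@@H]3OP(=O)(O)OC[C@H]3O2)c(=O)[nH]c1=O`; in a functional assay on L1210 cells (Mus musculus) (on this read-out lower numbers stand for stronger inhibition and higher numbers for weaker inhibition), compound 1 reports only a limit, > 500 ug/mL
compound 2, `CCCCc1cn([C@H]2C[C@H](O)[C@@H](CO)O2)c(=O)[nH]c1=O`; in this assay compound 2 reports only a limit, > 500 ug/mL
compound 3, `CCCc1cn([C@H]2C[C@H](O)[C@@H](CO)O2)c(=O)[nH]c1=O`; in this assay compound 3 reports only a limit, > 500 ug/mL

Compound 1 stands where every measured value of the series stands: the limit of > 500 ug/mL in this assay, at which 3 of the 3 values shown sit. No number exists anywhere in the set, so compound 1 can be placed neither above nor beneath the other two. For the measured compounds named here, the one step with a single change, a step that the two limits leave unreadable from compound 2 to compound 3, runs between two limits and therefore says nothing about its size or direction.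

The next compound, compound 4, `CCCCCCc1cn([C@H]2C[C@@H]3OP(=O)(O)OC[C@H]3O2)c(=O)[nH]c1=O`, carries the change (hexyl in place of isopropyl on an aromatic carbon). Going by the values given here, no measured step touches this position on the core of compound 1; the unreadable step between compound 2 and compound 3 concerns a chain on another core and gives no guidance.

With three limits and no readable step, the expectation for compound 4 is that it too sits at the limit, with the step of a number no higher from compound 1 to compound 4 (the limit leaves the size open) expected to show nothing beyond the scatter. Compound 4 is estimated at 500 ug/mL, between 200 ug/mL and 1000 ug/mL.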

Compound 4, concentration for 50% inhibition: > 500 ug/mL
Compound 4 was reported as a limit; the forecaster's own chance of this, stated with the estimate: 80%; the middle value lies on the limit itself.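

In this assay compound 4 reports only a limit, > 500 ug/mL, so the step between compound 1 and compound 4 cannot be read. The compounds shown leave open whether any change of alkyl chain alters inhibition in this assay at all, with every value at one limit: the limit of > 500 ug/mL in this assay, at which 4 of the 4 values shown sit.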